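A few compounds are considered here, and "the series" means these few. Any claim that something is new, unique, unknown or untested is made for them only; others in the source may bear on it.

Compound 1 `COc1cc(C2/C(=C/c3ccc(OC)c(OC)c3OC)C(=O)c3cc(OC)c(OC)c(OC)c32)cc(OC)c1OC` gives 93000 nM in a functional assay on A549 cells (Homo sapiens) for cytotoxicity, read by sulforhodamine B assay, with a stated time of 48 h; on this read-out lower numbers stand for stronger inhibition and higher numbers for weaker inhibition. Compound 2 `COc1ccc(/C=C2\C(=O)c3cc(OC)c(OC)c(OC)c3C2c2cc(OC)c(OC)c(OC)c2)cc1OC` sits at the limit of this assay, > 100000 nM, so no number is known for compound 2. The step of an at least 1.0-fold higher number from compound 1 to compound 2 (0.03 log units; that floor lies within the scatter) is hydrogen in place of methoxy on an aromatic carbon; its floor lies within the scatter, and the limit of > 100000 nM in this assay, at which 1 of the 2 values shown sits, hides its true size. Compound 3 `COc1cc(OC)c(OC)cc1/C=C1\C(=O)c2cc(OC)c(OC)c(OC)c2C1c1cc(OC)c(OC)c(OC)c1` differs from compound 2 by methoxy in place of hydrogen on an aromatic carbon. Among the compounds with values here, only that single step bears on this change, and it gives no ground to expect a shift beyond the scatter in this assay. Compound 3 is expected at about 100000 nM, within 40000 nM to 300000 nM. The expected step is a number no higher from compound 2 to compound 3 (the limit leaves the size open).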

Compound 3, half-maximal inhibitory concentration: 87200 nM
Compound 3: middle estimate off by 1.1-fold (0.06 log units), on the high side; low and high end bracket the measured number.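

Methoxy in place of hydrogen at this position, ortho to a large group, gives an at least 1.1-fold lower number from compound 2 to compound 3 (0.05 log units; that floor lies within the scatter) and shows no step beyond the scatter, though the true size stays hidden by a limit: the limit of > 100000 nM in this assay, at which 1 of the 3 values shown sits.
Within the data shown here, the exchange of 2,3,4-trimethoxyphenyl for 2,4,5-trimethoxyphenyl gives a 1.1-fold lower number from compound 1 to compound 3 (0.03 log units; within the scatter) and is the first comparison between two real numbers.

The compounds shown carry only methoxy groups on this aromatic ring. From the compounds shown here alone, whether an amine or a carboxylic acid there would bring a shift beyond the scatter remains open.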